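The source may hold more compounds than are shown below. What is called first, only, known or untested is meant among the compounds shown, and "the series" means these compounds.

Going by the values given here, compound 1 `COc1ccc(C(=O)NCc2ccc(CNS(=O)(=O)c3ccccc3)cc2)cc1` gives 1000 nM in an assay on MDA-MB-231 cells for binding affinity to C-X-C chemokine receptor type 4 (Homo sapiens), read by immunofluorescence and microscopy, with stated times of 10 min and 30 min (on this read-out lower numbers stand for an effect already at smaller amounts and higher numbers for an effect only at larger amounts of compound), the higher of the two numbers measured so far; compound 2 `COc1ccc(C(=O)NCc2ccc(CNS(=O)(=O)c3ccc(C)cc3)cc2)cc1` gives 100 nM, and the step of a 10-fold lower number from compound 1 to compound 2 (1.00 log units; beyond the scatter) came from methyl in place of hydrogen on an aromatic carbon. Compound 3 `O=C(NCc1ccc(CNS(=O)(=O)c2ccccc2)cc1)c1ccc([N+](=O)[O-])cc1` differs from compound 1 by nitro in place of methoxy on an aromatic carbon. Among the compounds with values here, no measured step touches that ring, so the one known step offers no direct guide, and no change beyond the scatter is expected. The expected step is no change at the digits printed from compound 1 to compound 3 (within the scatter), giving compound 3 an estimated 1000 nM, within 300 nM to 3000 nM.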

Compound 3, effective concentration (reported as EC, without a stated level of effect): 100 nM
Estimate against measurement, compound 3: 10-fold (1.00 log units) above, outside the stated range (below it).
By their numbers in this assay, from the lowest: compounds 2 and 3 (each within the scatter of the next); then compound 1.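

The ring that carries the methoxy group, para to a large group, is not a silent part of the molecule: in this assay nitro in place of methoxy gives a 10-fold lower number from compound 1 to compound 3 (1.00 log units; beyond the scatter) and so moves the number beyond the scatter. A change on this ring can therefore matter, just as the earlier methyl step on the other aromatic ring did. No evidence at hand explains this step.

Going by these compounds, it remains open how an amine or a carboxylic acid at this place would read. On these data alone, whether methyl and nitro together would lower the number further also remains unknown.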